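Acetamido in place of dimethylamino on the aryl ring

The compounds below may be only part of what the source reports. "The series", "measured", "known", "first", "only" and "open" are said of these compounds alone.

Compound 3 `Cc1cc(C(=O)Nc2nn[nH]n2)nc(-c2ccc(N(C)C)cc2)c1` gives 24% in a functional assay on the whole organism with Rattus norvegicus as the target, at a dose of 3 mg/kg by the oral route; a lower number here means a weaker effect, a higher number a stronger effect of the compound at the dose given. Its number is the lowest of the three measured, though compound 1 `COc1cc(C(=O)Nc2nn[nH]n2)nc(-c2ccc(NC(C)=O)cc2)c1` lies within the usual scatter of it, while compound 2 `CNc1ccc(-c2cccc(C(=O)Nc3nn[nH]n3)n2)cc1`, at 83%, stands well beyond the scatter above both. Compound 4 `CC(=O)Nc1ccc(-c2cc(C)cc(C(=O)Nc3nn[nH]n3)n2)cc1` differs from compound 3 in one place: acetamido in place of dimethylamino on an aromatic carbon. Going by the values given here, no measured pair differs by this change alone, so its size has not been seen directly. Compound 1 carries the same acetamido group and gives 27% in this assay, a number close to that of compound 3. On that ground a step of a number 3 percentage points higher from compound 3 to compound 4 (within the scatter) is expected, none beyond the scatter in either direction. Compound 4 is therefore estimated at 27%, with a range from 10% to 48%.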

Compound 4, a percentage reported as inhibition, in the whole organism at one dose (the size of the read-out at that dose, not a potency): 32%
Compound 4: middle estimate off by 5 percentage points, on the low side; the measured number falls inside the stated range.
By their numbers in this assay, from the lowest: compounds 3, 1 and 4 (each within the scatter of the next); then compound 2.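

In this assay, acetamido in place of dimethylamino on an aromatic carbon, para to a large group, gives a number 8 percentage points higher from compound 3 to compound 4 (within the scatter) and so shows no step beyond the scatter when the change is seen alone. Methyl in place of methoxy on the shared core likewise gives a number 5 percentage points higher from compound 1 to compound 4 (within the scatter) and adds a second change with no step beyond the scatter. No available evidence bears on these steps.

Compound 2 gives 83% but differs from compound 4 in more than one place, so the source of its higher number cannot be read. A primary amine at the same place on the methyl-bearing core would test whether the nitrogen substituent alone carries that gap.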